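Swapping a Halophenol Arm for a Fused Heteroaromatic

The compounds below may be only part of what the source reports. "The series", "measured", "known", "first", "only" and "open" are said of these compounds alone.

Compound 1 `CCOC(=O)C1=C(Nc2ccccc2)S/C(=C\c2ccc(Br)c(O)c2)C1=O` and compound 2 `CCOC(=O)C1=C(Nc2ccc(CC)cc2)S/C(=C\c2ccc[nH]2)C1=O` share the same core. In a functional assay on A549 cells (Homo sapiens) for inhibition, read by MTT assay, with a stated time of 72 h, tested at 10 uM (a higher number here means more inhibition at the concentration tested (going by the name of the read-out), a lower number less inhibition), compound 1 gives 13.6%, and compound 2 gives 17.5%; compound 1 holds the lowest of the two numbers, but its gap to compound 2 lies within the scatter, so neither can be called weaker. Compound 3 `CCOC(=O)C1=C(Nc2ccccc2)S/C(=C\c2cc3ccncc3[nH]2)C1=O` differs from compound 1 in one place: a group of 9 heavy atoms (7 carbon, 2 nitrogen; one five-membered aromatic ring with 1 hetero atom, one six-membered aromatic ring with 1 hetero atom) in place of a group of 8 heavy atoms (6 carbon, 1 oxygen, 1 bromine; one six-membered aromatic ring of carbon only), on a double-bonded chain carbon bound to a double-bonded ring carbon. Within the data shown here, no measured pair shows a step of this kind, so no direction is known. The expected step of a number 4.4 percentage points higher from compound 1 to compound 3 (within the scatter) is small, within the scatter. Compound 3 is estimated to give 18%, ranging from 5% to 38%.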

Compound 3, a percentage reported as inhibition, at one concentration (the size of the read-out at that concentration, not a potency): 17.1%
Compound 3: the middle estimate sits 0.9 percentage points above what was measured; low and high end bracket the measured number.
By their numbers in this assay, from the lowest: compounds 1, 3 and 2 (each within the scatter of the next).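

Placing the group with one five-membered and one six-membered aromatic ring, both with a hetero atom, on the double-bonded chain carbon in place of 4-bromo-3-hydroxyphenyl gives, in this assay, a number 3.5 percentage points higher from compound 1 to compound 3 (within the scatter). This position therefore accepts the exchange of a bromine-and-oxygen-bearing carbon ring for a nitrogen-bearing two-ring group with no readable change in this read-out. What the compounds shown leave open is whether a plain phenyl, a 3-hydroxyphenyl or a 4-bromophenyl at this place would read any differently. No measurement shown bears on this result.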